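A few compounds are considered here, and "the series" means these few. Any claim that something is new, unique, unknown or untested is made for them only; others in the source may bear on it.

Series notes. The shared core carries a varied aryl group on a double-bonded chain carbon bound to a double-bonded ring carbon. In a functional assay on K562 cells (Homo sapiens) for inhibition, read by MTT assay, with a stated time of 72 h (on this read-out higher numbers stand for weaker inhibition and lower numbers for stronger inhibition), compound 1 `CCOC(=O)C1=C(Nc2ccccc2)S/C(=C\c2ccc(O)c(O)c2)C1=O` gives 5200 nM; compound 2 `CCOC(=O)C1=C(Nc2ccccc2)S/C(=C\c2cccc(C(=O)O)c2)C1=O` gives 16200 nM; compound 3 `CCOC(=O)C1=C(Nc2ccccc2)S/C(=C\c2ccc[nH]2)C1=O` gives 71000 nM. Compound 3 therefore stands highest of the three numbers, with a 4.4-fold higher number from compound 2 to compound 3 (0.64 log units; beyond the scatter) and a 14-fold higher number from compound 1 to compound 3 (1.14 log units; beyond the scatter); between the two aryl compounds the step is a 3.1-fold higher number from compound 1 to compound 2 (0.49 log units; beyond the scatter).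

Compound 4 `CCOC(=O)C1=C(Nc2ccccc2)S/C(=C\c2cc3cccnc3[nH]2)C1=O` differs from compound 3 in one place: a group of 9 heavy atoms (7 carbon, 2 nitrogen; one five-membered aromatic ring with 1 hetero atom, one six-membered aromatic ring with 1 hetero atom) in place of a group of 5 heavy atoms (4 carbon, 1 nitrogen; one five-membered aromatic ring with 1 hetero atom), on a double-bonded chain carbon bound to a double-bonded ring carbon. For the measured compounds named here, no measured step adds a fused ring to the five-membered group; the steps at hand only show that the 1H-pyrrol-2-yl compound 3 lies well above the two phenyl compounds. The estimate for compound 4 can rest only on that spread, so a lower number than compound 3 is expected, with wide uncertainty, amounting to a 2.4-fold lower number from compound 3 to compound 4 (0.37 log units; beyond the scatter). Compound 4 is expected to give 30000 nM in this assay, with a range from 8000 nM to 100000 nM.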

Compound 4, half-maximal inhibitory concentration: > 100000 nM
Compound 4: a limit, no number; the forecaster's own chance of this, stated with the estimate: 15%; middle value at least 3.3-fold (0.52 log units) away from the limit.
By their numbers in this assay, from the lowest: compound 1; then compound 2; then compound 3. At a limit, above all of these: compound 4.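

Compound 4 yields a limit, not a number, in this assay: the limit of > 100000 nM in this assay, at which 1 of the 4 values shown sits.

Set against the 1H-pyrrol-2-yl compound, the larger group gives an at least 1.4-fold higher number from compound 3 to compound 4 (0.14 log units; that floor lies within the scatter), so the floor of this step does not separate the two compounds, yet the added six-membered aromatic ring brings no measurable gain at this position. The floors against the two phenyl compounds are clearer, at an at least 6.1-fold higher number from compound 2 to compound 4 (0.79 log units; beyond the scatter) and an at least 19-fold higher number from compound 1 to compound 4 (1.28 log units; beyond the scatter), so neither five-membered aromatic group shown here approaches the 3,4-dihydroxyphenyl compound.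

Going by these compounds, how far compound 4 lies beyond its limit remains unknown. Also open, on these data alone, is whether a hydroxyl group or a carboxylic acid on the 1H-pyrrol-2-yl group would bring the number down toward that of compound 1.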